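Pyridin-2-yl for Benzyl on a Triazole-Linked Furanone

The source may report more compounds than this note shows. Statements on the series, on what has been measured and on what is new or still open speak of the compounds shown alone.

Compound 1 `O=C1O/C(=C\Cn2cc(Cc3ccccc3)nn2)C(OCc2ccccc2)=C1OCc1ccccc1` carries a benzyl group on its triazole ring. In a functional assay on U-937 cells (Homo sapiens) for antiproliferative activity, read by MTT assay, with a stated time of 24 h (a lower number here means a stronger inhibitor, a higher number a weaker inhibitor), compound 1 gives > 100000 nM, which is a limit of the assay rather than a number. Compound 1 therefore sits at the limit of > 100000 nM in this assay, at which 1 of the 2 values shown sits. Compound 2 `CC(C)(C)c1ccc(-c2cn(CCC3(O)NC(=O)C(OCc4ccccc4)=C3OCc3ccccc3)nn2)cc1` is built on a different core, and in this assay compound 2 gives 56500 nM. Compound 3 `O=C1O/C(=C\Cn2cc(-c3ccccn3)nn2)C(OCc2ccccc2)=C1OCc1ccccc1` differs from compound 1 by pyridin-2-yl in place of benzyl on an aromatic carbon. Within the data shown here, no step between two measured compounds shows what this exchange does, so no shift beyond the usual scatter is expected in either direction. Compound 3 is expected to remain near the limit where compound 1 sits, with an estimated value of 100000 nM and a range from 30000 nM to 300000 nM. The expected step of a number no higher from compound 1 to compound 3 (the limit leaves the size open) is accordingly small.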

Compound 3, half-maximal inhibitory concentration: 70200 nM
Compound 3: the middle estimate sits 1.4-fold (0.15 log units) above what was measured; the measured number falls inside the stated range.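

Placing pyridin-2-yl in place of benzyl at this position gives, in this assay, an at least 1.4-fold lower number from compound 1 to compound 3 (0.15 log units; that floor lies within the scatter). Compound 1 remains a limit of the assay and not a number: the limit of > 100000 nM in this assay, at which 1 of the 3 values shown sits. Going by these compounds, the true size of the step therefore stays open, but the core of compound 1 now has a real number in compound 3, 70200 nM, against which other groups at this position can be compared.

The compounds shown do not separate the ring nitrogen that enters from the one carbon that leaves, so neither can be tied to the step. A plain phenyl group on the same aromatic carbon would tell these two apart, and pyridin-3-yl or pyridin-4-yl there would show whether the place of the ring nitrogen matters.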